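Cytotoxicity notes on the aryl change in this series

The source may report more compounds than this note shows. Statements on the series, on what has been measured and on what is new or still open speak of the compounds shown alone.

Compound 1 `C[C@]1(CN2CCc3nc(N4CCC(F)(F)CC4)ccc3C2)Cn2cc([N+](=O)[O-])nc2O1` has no result in an ADME assay on Vero cells (Chlorocebus sabaeus) for cytotoxicity, read by MTT assay, with a stated time of 72 h; a lower number here means that less compound is tolerated, a higher number that more compound is tolerated "not determined" (no result reported). Compound 2 `C[C@]1(CN2CCc3nc(-c4ccc(C(F)(F)F)cc4)ccc3C2)Cn2cc([N+](=O)[O-])nc2O1` gives in this assay only a limit, > 32 ug/mL. Compound 3 `C[C@]1(CN2CCc3nc(-c4cccc(F)c4F)ccc3C2)Cn2cc([N+](=O)[O-])nc2O1` likewise gives in this assay only a limit, > 32 ug/mL. The step that the two limits leave unreadable from compound 2 to compound 3 therefore cannot be read. Compound 3 thus stands at the limit (the limit of > 32 ug/mL in this assay, at which 2 of the 3 values shown sit), with one further limit and one entry without a number beside it.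

Compound 4 `C[C@]1(CN2CCc3nc(-c4cc(Cl)ccc4F)ccc3C2)Cn2cc([N+](=O)[O-])nc2O1` differs from compound 3 by 5-chloro-2-fluorophenyl in place of 2,3-difluorophenyl on an aromatic carbon. Among the measured compounds shown here, because the only comparable step that the two limits leave unreadable from compound 2 to compound 3 shows no readable size, the change to compound 4 is expected to leave this assay without a step beyond the scatter, and a further limit rather than a number is the most likely outcome. Compound 4 is expected at 40 ug/mL, with a range from 25 ug/mL to 100 ug/mL. This expectation corresponds to an estimated step that the limit leaves unreadable from compound 3 to compound 4.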

Compound 4, half-maximal cytotoxic concentration: > 32 ug/mL
Compound 4 ended at the assay's limit; the forecaster's own chance of this, stated with the estimate: 80%; the middle value lies beyond the limit too.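

In this assay compound 4 gives only a limit, > 32 ug/mL. Among the compounds shown here, with compound 2, compound 3 and compound 4 all at limits, no step among them can be read. The compounds shown leave open where their actual cytotoxic concentrations lie, and whether the aryl change alters them.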